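Triazole to pyrazole amide: expected lipophilicity shift

This account rests on a few compounds, and the source may have more. Where it says the series, first, only, none or still open, it means among the compounds named here.

Compound 1 `NCc1csc(NC(=O)c2cnn[nH]2)n1` and compound 2 `NCc1csc(NC(=O)c2ncccn2)n1` share one core and differ in the group on the carbonyl carbon. In a physicochemical assay for lipophilicity, read by HPLC, at pH 3.0 (on this read-out higher numbers stand for higher lipophilicity and lower numbers for lower lipophilicity), compound 1 gives -0.2 and compound 2 gives -0.2; the two stand level within the scatter, so no order between them can be read. Compound 3 `NCc1csc(NC(=O)c2ccn[nH]2)n1` is not yet measured. Its change from compound 1 is 1H-pyrazol-5-yl in place of 1H-1,2,3-triazol-5-yl on a carbonyl carbon. Within the data shown here, no measured step of this kind exists in the set. The step of a number 0.40 log units higher from compound 1 to compound 3 (beyond the scatter) is expected to be a modest rise, likely beyond the scatter. Compound 3 is estimated at 0.2, with a range from -0.2 to 0.6.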

Compound 3, distribution coefficient: 0
For compound 3 the middle estimate is 0.20 log units above the measured one; the range from low to high includes it.
By their numbers in this assay, from the lowest: compounds 1, 2 and 3 (each within the scatter of the next).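

In this assay, among these compounds, 1H-pyrazol-5-yl in place of 1H-1,2,3-triazol-5-yl on a carbonyl carbon gives a number 0.20 log units higher from compound 1 to compound 3 (within the scatter), the first measured step at this position. This exchange therefore does not separate compound 3 from compound 1 on this read-out, and the step gives no direction that can be relied on. No measured evidence bears on the reason for this result.

From the compounds shown here alone, whether a group without an aromatic ring, such as a longer alkyl chain or a piperidine, would stand apart on this carbonyl carbon remains open. Going by these compounds, whether the level read-out holds at other pH values also remains open.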